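A few compounds are considered here, and "the series" means these few. Any claim that something is new, unique, unknown or untested is made for them only; others in the source may bear on it.

Of the compounds shown here, three built on one shared core have been measured in a functional assay, with a stated time of 10 min; on this read-out lower numbers stand for stronger inhibition and higher numbers for weaker inhibition. Compound 1 `CCOC(=O)c1cnn(-c2nc(-c3cccc(OC)c3OC)c(C#N)c(=O)n2C)c1N` gives 67 ug/mL, compound 2 `CCOC(=O)c1cnn(-c2nc(-c3ccccc3O)c(C#N)c(=O)n2C)c1N` gives 58 ug/mL, and compound 3 `CCOC(=O)c1cnn(-c2nc(-c3ccc(N(C)C)cc3)c(C#N)c(=O)n2C)c1N` gives 119 ug/mL, the highest of the three numbers. Among the measured compounds shown here, every measured step so far exchanges the aryl group on the core: a 1.2-fold lower number from compound 1 to compound 2 (0.06 log units; within the scatter), a 1.8-fold higher number from compound 1 to compound 3 (0.25 log units; within the scatter) and a 2.1-fold higher number from compound 2 to compound 3 (0.31 log units; beyond the scatter). Compound 4 `CCOC(=O)c1cnn(-c2nc(-c3ccco3)c(C#N)c(=O)n2C)c1N` changes the same position once more, (furan-2-yl in place of 4-(dimethylamino)phenyl on an aromatic carbon). For the measured compounds named here, no measured step involves a five-membered ring, so the expectation rests on the aryl exchanges already seen, all of which stayed modest. Compound 4 is therefore expected to show a 1.5-fold lower number from compound 3 to compound 4 (0.17 log units; within the scatter), a small move to a lower number in this assay, with an estimate of 80 ug/mL and a range from 35 ug/mL to 200 ug/mL.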

Compound 4, half-maximal inhibitory concentration: 104 ug/mL
The estimate for compound 4 lay 1.3-fold (0.11 log units) below the measured number; low and high end bracket the measured number.
By their numbers in this assay, from the lowest: compounds 2, 1, 4 and 3 (each within the scatter of the next, the first and the last beyond it).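

In this assay, among the compounds shown here, furan-2-yl puts a five-membered aromatic ring with one hetero atom at this position for the first time, and compound 4 stays within the scatter of all three compounds with six-membered aryl groups (a 1.1-fold lower number from compound 3 to compound 4 (0.06 log units; within the scatter); a 1.8-fold higher number from compound 2 to compound 4 (0.25 log units; within the scatter); a 1.6-fold higher number from compound 1 to compound 4 (0.19 log units; within the scatter)). Replacing a six-membered aryl group with this smaller ring therefore gives no readable step here. Nothing available explains this result.

Going by these compounds, it remains open whether a pyridine ring, a thiophene ring or a furan carrying a carboxylic acid at this position would give a step beyond the scatter.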